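The source may report more compounds than this note shows. Statements on the series, on what has been measured and on what is new or still open speak of the compounds shown alone.

The measured compounds:
compound 1, `Cc1cccc(OC(c2ccc(Br)cc2)C2CCN(C(C)CCNC(=O)c3c(Cl)cncc3Cl)CC2)n1`: 6500 nM
compound 2, `CCO/N=C(/c1ccc(Br)cc1)C1CCN(C(CC)CCNC(=O)c2c(C)cc[n+]([O-])c2C)CC1`: > 177000 nM

In an ADME assay on PBMC cells (Homo sapiens) for cytotoxicity (a higher number here means that more compound is tolerated, a lower number that less compound is tolerated), compound 1 gives 6500 nM. For compound 2 the figure > 177000 nM is a limit of this assay, not a number. Compound 2 therefore stands at the edge of what the measurement can report: the limit of > 177000 nM in this assay, at which 1 of the 2 values shown sits. Going by the values given here, compound 1 and compound 2 differ in more than one place, so no step between them can be drawn. Only what their two values show can be said, namely that compound 1 sits at a number and compound 2 at a limit.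

Compound 3, `CCO/N=C(/c1ccc(Br)cc1)C1CCN(CCCNC(=O)c2c(C)cc[n+]([O-])c2C)CC1`, is still to be measured in this assay. It differs from compound 2 in one place: hydrogen in place of ethyl on a saturated chain carbon bound to an amine nitrogen in a ring and a saturated chain carbon. A saturated chain carbon bound to an amine nitrogen in a ring loses an ethyl and carries a hydrogen instead; nothing else moves.

In this assay the step from compound 2 to compound 3 is expected to be none beyond the scatter. Compound 3 is expected in this assay at 150000 nM, within a range from 50000 nM to 400000 nM. That estimate means a step of an at least 1.1-fold lower number from compound 2 to compound 3 (0.07 log units; that floor lies within the scatter), expected to stay within the scatter, with a fair chance that this assay again reports only a limit for compound 3.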

Compound 3, half-maximal cytotoxic concentration: 7500 nM
Compound 3: the middle estimate sits 20-fold (1.30 log units) above what was measured; the whole stated range lies above it.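

In this assay, replacing the ethyl on a saturated chain carbon bound to an amine nitrogen in a ring and a saturated chain carbon with hydrogen is a large change, with an at least 23-fold lower number from compound 2 to compound 3 (1.37 log units; beyond the scatter). This is the first step that can be read among the compounds shown, and it marks this carbon as a place where a single change, the loss of the ethyl, carries a result beyond the scatter. The full size of the step cannot be given because compound 2 has a limit and not a number: the limit of > 177000 nM in this assay, at which 1 of the 3 values shown sits.

The compounds shown leave open whether the tolerance seen with the ethyl would also hold with another group on this carbon, such as a propyl or a cyclopropyl group, and whether it would hold with the rest of the structure changed. Going by these compounds alone, no steps involving compound 1 can be read, as it differs from each of the other two compounds in more than one place.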